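The source may hold more compounds than are shown below. What is called first, only, known or untested is meant among the compounds shown, and "the series" means these compounds.

Within the data shown here, compound 1, whose structure is `C=CCNC(=C\C(=O)/C=C/c1ccc(O)c(OC)c1)/C=C/c1ccc(O)c(OC)c1`, is one of three compounds measured in a functional assay on HT-29 cells (Homo sapiens) for inhibition, read by sulforhodamine B assay, with a stated time of 72 h; a higher number here means a weaker inhibitor, a lower number a stronger inhibitor. In this assay compound 1 gives 24600 nM, the highest of the two numbers reported. Compound 3, with structure `CC(=O)Oc1ccc(/C=C/C(=O)/C=C(/C=C/c2ccc(OC(C)=O)cc2)NCC(C)C)cc1`, gives 22600 nM in this assay, a number that sits within the usual scatter of compound 1, so the two cannot be told apart. Compound 2, with structure `COc1cc(/C=C/C(=O)/C=C(/C=C/c2ccc(OC(C)=O)c(OC)c2)NC2CCCCC2)ccc1OC(C)=O`, reports only a limit in this assay, > 25000 nM, and not a number. The existence of that limit is recorded as the limit of > 25000 nM in this assay, at which 1 of the 3 values shown sits.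

The piece follows the step from compound 1 to compound 4, whose structure is `COc1cc(/C=C/C(=O)/C=C(/C=C/c2ccc(O)c(OC)c2)NCC(C)C)ccc1O`. The two differ in a single place: isopropyl in place of vinyl on a saturated chain carbon bound to an amine nitrogen. Cut one bond further out, this reads as allyl to isobutyl, or allylamino to isobutylamino.

Among the measured compounds shown here, no step between two measured compounds is recorded that would show how this kind of change moves the numbers in this assay. Compound 3 carries the isobutylamino group and sits within the scatter of compound 1, although compound 3 also differs elsewhere. The step is therefore expected to be small, in no particular direction, and not beyond the scatter: a 1.1-fold lower number from compound 1 to compound 4 (0.03 log units; within the scatter). Compound 4 is expected to give about 23000 nM in this assay, within a range from 10000 nM to 50000 nM.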

Compound 4, half-maximal inhibitory concentration: 24000 nM
For compound 4 the middle estimate is 1.0-fold (0.02 log units) below the measured one; low and high end bracket the measured number.
By their numbers in this assay, from the lowest: compounds 3, 4 and 1 (each within the scatter of the next). At a limit, above all of these: compound 2.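

In this assay, among these compounds, the earlier compounds offered no step at this position, and the change from allylamino to isobutylamino now supplies one: a 1.0-fold lower number from compound 1 to compound 4 (0.01 log units; within the scatter). At this saturated chain carbon bound to an amine nitrogen, isopropyl in place of vinyl removes a double bond outside aromatic rings and leaves the two compounds indistinguishable, so this particular swap gives no sign that the number responds to the change. This flat reading needs caution, as compound 2 reports only a limit and the step was read close to it: the limit of > 25000 nM in this assay, at which 1 of the 4 values shown sits.

The compounds shown leave open whether a carboxylic acid, a second amine or a longer chain at this place would move the number beyond the scatter. They also leave open whether allyl to isobutyl would read the same way on a compound of the same family that gives a much lower number, far from that limit.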